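A few compounds are considered here, and "the series" means these few. Any claim that something is new, unique, unknown or untested is made for them only; others in the source may bear on it.

Working notes on the series, all in a functional assay on MCF7 cells (Homo sapiens) for cytotoxicity, read by MTT assay, with a stated time of 96 h; a lower number here means a stronger inhibitor, a higher number a weaker inhibitor. Compound 1 (`COc1cc(C(=O)c2cn(-c3ccccc3)cc2-c2ccccc2[N+](=O)[O-])cc(OC)c1OC`) gives 49 nM, compound 2 (`COc1cc(C(=O)c2cn(-c3cccc(N)c3)cc2-c2ccccc2Cl)cc(OC)c1OC`) gives 40 nM, and compound 3 (`COc1cc(C(=O)c2cn(-c3cccc(N)c3)cc2-c2ccccc2[N+](=O)[O-])cc(OC)c1OC`) gives 14 nM, the lowest of the three numbers.

Compound 4 (`COc1cc(C(=O)c2cn(-c3ccc(N)cc3)cc2-c2ccccc2[N+](=O)[O-])cc(OC)c1OC`) is still unmeasured and has the same atoms as compound 3, joined differently: 4-aminophenyl in place of 3-aminophenyl on an aromatic nitrogen, with 4-aminophenyl in place of 3-aminophenyl on an aromatic nitrogen.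

Among the compounds with values here, no measured pair moves the amino group, so the data give no direct reading of this change. Two steps set the scale. Amino in place of hydrogen gives a 3.5-fold lower number from compound 1 to compound 3 (0.54 log units; beyond the scatter), and nitro in place of chloro gives a 2.9-fold lower number from compound 2 to compound 3 (0.46 log units; beyond the scatter); both are modest. Compound 4 keeps both the amino and the nitro groups, so a large loss is not expected, although part of the amino gain could go.

The estimate amounts to a 1.6-fold higher number from compound 3 to compound 4 (0.20 log units; within the scatter), a slightly higher number that is expected to stay within the scatter. For compound 4 the expected value is 22 nM, with an estimated range from 7 nM to 70 nM.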

Compound 4, half-maximal inhibitory concentration: 53 nM
Compound 4: middle estimate off by 2.4-fold (0.38 log units), on the low side; low and high end bracket the measured number.
By their numbers in this assay, from the lowest: compound 3; then compounds 2, 1 and 4 (each within the scatter of the next).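

Where the amino group sits on the phenyl carried by the aromatic nitrogen matters in this assay: 4-aminophenyl in place of 3-aminophenyl gives a 3.8-fold higher number from compound 3 to compound 4 (0.58 log units; beyond the scatter), a step about as large as that from adding the amino group in the first place. With 4-aminophenyl, amino in place of hydrogen gives only a 1.1-fold higher number from compound 1 to compound 4 (0.03 log units; within the scatter), whereas with 3-aminophenyl it gives a 3.5-fold lower number from compound 1 to compound 3 (0.54 log units; beyond the scatter), so the earlier benefit of the amino group holds for 3-aminophenyl but does not carry over to 4-aminophenyl. Nothing at hand accounts for this difference between the two placements.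

On these data alone, whether 4-aminophenyl would show the same step alongside the chloro group of compound 2 remains open. Also open, as far as these compounds go, is whether a hydroxyl or an acetamide in place of the amino group would depend on placement in the same way.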